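The compounds below may be only part of what the source reports. "The series", "measured", "known", "first", "only" and "open" are said of these compounds alone.

In a functional assay on HeLa cells (Homo sapiens) for cytotoxicity, read by MTT assay, with a stated time of 48 h, tested at 25 uM (a lower number here means a weaker effect, a higher number a stronger effect of the compound at the concentration tested), compound 3, with the structure `CS(=O)(=O)c1ccc(Cc2n[nH]c(=S)n2/N=C/c2ccccc2Cl)cc1`, gives 36.3%, the highest of the three numbers measured here. Compound 1, with the structure `CSc1ccc(/C=N/n2c(Cc3ccc(S(C)(=O)=O)cc3)n[nH]c2=S)cc1`, gives 32.7%, and the step of a number 3.6 percentage points higher from compound 1 to compound 3 (within the scatter) lies within the scatter, so these two cannot be told apart. Compound 2, with the structure `CS(=O)(=O)c1ccc(Cc2n[nH]c(=S)n2/N=C/c2cccnc2)cc1`, gives 19.4%; the step of a number 16.9 percentage points higher from compound 2 to compound 3 (beyond the scatter) and the step of a number 13.3 percentage points lower from compound 1 to compound 2 (beyond the scatter) are the only ones beyond the scatter, and both exchange the whole aromatic group carried on the carbon with a double bond to nitrogen. Compound 4, with the structure `CS(=O)(=O)c1ccc(Cc2n[nH]c(=S)n2/N=C/c2ccccc2F)cc1`, differs from compound 3 by a single small change: fluoro in place of chloro on an aromatic carbon. Among the measured compounds shown here, no measured step exchanges one halogen for another on an aromatic carbon, so nothing here speaks directly to this change. The nearest guide is that compound 3 and compound 1, carrying quite different groups on the carbon with a double bond to nitrogen, still lie within the scatter of each other. A step of a number 3.3 percentage points lower from compound 3 to compound 4 (within the scatter) is therefore expected to stay within the scatter. Compound 4 is estimated to give 33%, with a range from 20% to 46%.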

Compound 4, a percentage reported as activity, at one concentration (the size of the read-out at that concentration, not a potency): 14%
Compound 4: middle estimate off by 19 percentage points, on the high side, and the stated range ends above it.
By their numbers in this assay, from the lowest: compounds 4 and 2 (each within the scatter of the next); then compounds 1 and 3 (each within the scatter of the next).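

In this assay, a number 22.3 percentage points lower from compound 3 to compound 4 (beyond the scatter) shows that this aromatic carbon, ortho to a large group, is sensitive: exchanging one halogen atom for another moves the read-out beyond the scatter. The result also changes where the 2-fluorophenyl compound sits among the others, since a number 18.7 percentage points lower from compound 1 to compound 4 (beyond the scatter) is beyond the scatter, while a number 5.4 percentage points lower from compound 2 to compound 4 (within the scatter) is within it, so compound 4 cannot be told apart from the pyridin-3-yl compound. A swap of a single atom here can therefore reach beyond the scatter, just as exchanging the whole aromatic group did with compounds 1 and 2.

Nothing available explains why chloro and fluoro part so clearly here. The compounds shown leave open whether bromo, methyl or an amine on this same aromatic carbon would read like chloro or like fluoro.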